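Replacing the phenyl group of compound 3

This account rests on a few compounds, and the source may have more. Where it says the series, first, only, none or still open, it means among the compounds named here.

Measured so far in a physicochemical assay for lipophilicity, at pH 7.4; on this read-out lower numbers stand for lower lipophilicity and higher numbers for higher lipophilicity:
- compound 1 `Cc1nc(C)c(-c2nnc(-c3ccc(OC(C)C)c(Cl)c3)s2)s1`: 7.76
- compound 2 `CC(C)Oc1ccc(-c2nnc(-c3ccno3)s2)cc1Cl`: 6.93
- compound 3 `CC(C)Oc1ccc(-c2nnc(-c3ccccc3)s2)cc1Cl`: 8.65

Compound 3 stands highest of the three in this assay, at 8.65. Compound 4 `CC(C)Oc1ccc(-c2nnc(-c3cncn3C)s2)cc1Cl` differs from it in one place: 1-methyl-1H-imidazol-5-yl in place of phenyl on an aromatic carbon, (1-methyl-1H-imidazol-5-yl in place of phenyl on an aromatic carbon). Among the measured compounds shown here, no measured compound carries this new group, so the closest guides are the two steps that end at phenyl and start from another five-membered aromatic ring. One is the modest a number 0.89 log units higher from compound 1 to compound 3 (beyond the scatter), starting from 2,4-dimethyl-1,3-thiazol-5-yl. The other is the large a number 1.72 log units higher from compound 2 to compound 3 (beyond the scatter), starting from 1,2-oxazol-5-yl. Both lie beyond the scatter and both rise on reaching phenyl, so leaving phenyl should bring a fall. Two steps are a thin basis, and the size remains uncertain. A large fall is expected, with an estimated step of a number 1.95 log units lower from compound 3 to compound 4 (beyond the scatter). The estimate for compound 4 is 6.7, with an expected range of 6 to 7.4.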

Compound 4, distribution coefficient: 5.7
Estimate against measurement, compound 4: 1.00 log units above, and the stated range ends above it.
By their numbers in this assay, from the lowest: compound 4; then compound 2; then compound 1; then compound 3.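

In this assay, among the compounds shown here, this position can reach lower numbers than the earlier compounds showed, with a fall (a number 2.95 log units lower from compound 3 to compound 4 (beyond the scatter)) even though phenyl and 1-methyl-1H-imidazol-5-yl have the same count of 6 heavy atoms and neither carries a net charge. The five-membered aromatic rings also differ clearly among themselves (a number 1.23 log units lower from compound 2 to compound 4 (beyond the scatter)) and (a number 2.06 log units lower from compound 1 to compound 4 (beyond the scatter)), so a ring of that size does not by itself set the number. No measured evidence here explains these differences.

The compounds shown do not separate what the methyl group contributes from what the ring with its 2 nitrogen atoms contributes. Going by these compounds, it also remains open where the read-out would fall with an amine or a carboxylic acid in this place.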